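Adding a Methoxy Group: What to Expect for Compound 4

A few compounds are considered here, and "the series" means these few. Any claim that something is new, unique, unknown or untested is made for them only; others in the source may bear on it.

Compound 1 `O=C(CCCCCCNC(=O)C(O)(O)C(F)(F)F)Nc1ccc(Cl)cc1`: 26900 nM
Compound 2 `O=C(CCCCCCNC(=O)C(O)(O)C(F)(F)F)Nc1ncc(-c2ccccc2)s1`: 17000 nM
Compound 3 `COc1ccc(OC)c(NC(=O)CCCCCCNC(=O)C(O)(O)C(F)(F)F)c1`: "not determined" (no result reported)

In a functional assay on cells (Panel NCI-60 (60 carcinoma cell lines), Homo sapiens) for inhibition, read by colorimetric assay, with a stated time of 3 days (a higher number here means a weaker inhibitor of growth, a lower number a stronger inhibitor of growth), compound 2 gives the lower of the two numbers available, yet compound 1 sits close enough that the two cannot be told apart. Compound 3 has no result in this assay, so it adds nothing to the comparison.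

Compound 4 `COc1ccc(-c2cnc(NC(=O)CCCCCCNC(=O)C(O)(O)C(F)(F)F)s2)cc1` is compound 2 with one change: methoxy in place of hydrogen on an aromatic carbon

Within the data shown here, no measured pair shows what such a change does in this assay. The expectation for the step from compound 2 to compound 4 is therefore a small one, likely no larger than the scatter, with the direction uncertain: a 1.1-fold lower number from compound 2 to compound 4 (0.05 log units; within the scatter). Compound 4 is estimated at 15000 nM, within a range from 6000 nM to 40000 nM.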

Compound 4, concentration for total growth inhibition: 8510 nM
The estimate for compound 4 lay 1.8-fold (0.25 log units) above the measured number, within the range that was stated.
By their numbers in this assay, from the lowest: compounds 4, 2 and 1 (each within the scatter of the next, the first and the last beyond it).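

Among these compounds, this is the first measured pair for this change: in this assay, methoxy in place of hydrogen on the six-membered aromatic ring gives a 2.0-fold lower number from compound 2 to compound 4 (0.30 log units; within the scatter), a step that stays within the scatter. So this place, para to a large group, accepts a group of 2 heavy atoms with no measurable loss of growth inhibition. The compounds shown leave open whether an amine or a carboxylic acid at the same place would shift the number beyond the scatter. Nothing measured here offers a reason for the size of this step.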